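From Benzylsulfamoyl to Diisobutylcarbamoyl

The source may report more compounds than this note shows. Statements on the series, on what has been measured and on what is new or still open speak of the compounds shown alone.

In a functional assay on NT2 cells (Homo sapiens) for inhibition (a higher number here means a weaker inhibitor, a lower number a stronger inhibitor), compound 2 `O=C(O)C[C@H](NC(=O)c1cncc(S(=O)(=O)NCc2ccccc2)c1)C(=O)CSCc1ccc(F)cc1` gives 59000 nM, within the scatter of compound 3 `O=C[C@H](CC(=O)O)NC(=O)c1cncc(S(=O)(=O)NC2CC2)c1` at 57000 nM. Compound 1 `CCCN(CCC)C(=O)c1cncc(C(=O)N[C@@H](CC(=O)O)C(=O)CSCc2ccc(F)cc2)c1` reaches only a limit, > 100000 nM. Compound 4 `CC(C)CN(CC(C)C)C(=O)c1cncc(C(=O)N[C@@H](CC(=O)O)C(=O)CSCc2ccc(F)cc2)c1` is still unmeasured and differs from compound 2 in one place: diisobutylcarbamoyl in place of benzylsulfamoyl on an aromatic carbon. Among the measured compounds shown here, the one measured step that bears on this change is benzylsulfamoyl in place of dipropylcarbamoyl, which gave an at least 1.6-fold lower number from compound 1 to compound 2 (0.22 log units; that floor lies within the scatter), a size known only as a floor because of the limit of > 100000 nM in this assay, at which 1 of the 3 values shown sits. This is weak guidance, but on that step a return to a carbamoyl group is expected to give a somewhat higher number in this assay. The estimated change is a 1.7-fold higher number from compound 2 to compound 4 (0.23 log units; within the scatter). For compound 4 the estimated value is 100000 nM, with an expected range of 40000 nM to 250000 nM.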

Compound 4, half-maximal inhibitory concentration: 39000 nM
For compound 4 the middle estimate is 2.6-fold (0.41 log units) above the measured one; the whole stated range lies above it.
By their numbers in this assay, from the lowest: compounds 4, 3 and 2 (each within the scatter of the next). At a limit, above all of these: compound 1.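

The change from benzylsulfamoyl to diisobutylcarbamoyl gives a 1.5-fold lower number from compound 2 to compound 4 (0.18 log units; within the scatter) and so does not separate the two groups at this position. Diisobutylamino in place of dipropylamino on the carbonyl carbon gives an at least 2.5-fold lower number from compound 1 to compound 4 (0.40 log units; beyond the scatter), which shows that the amine part of the carbamoyl group can change the number in this assay by a modest amount. That size is only a floor, because compound 1 stands at a limit: the limit of > 100000 nM in this assay, at which 1 of the 4 values shown sits.

Still open, going by these compounds, is whether a primary amide or a carboxylic acid on this aromatic carbon would differ from these groups by more than the scatter. The same question holds for a longer branched chain on the amide nitrogen.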